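Pyridinyl, Hydroxyphenyl and Phenyl on the Thioether Chain

The source may hold more compounds than are shown below. What is called first, only, known or untested is meant among the compounds shown, and "the series" means these compounds.

Compound 3 `CC(Sc1nc2c(cnn2C)c(=O)n1-c1ccccc1)c1cccc(O)c1` gives 100 nM in an assay on isolated protein for inhibition of retinal dehydrogenase 2 (Homo sapiens) (a higher number here means a weaker inhibitor, a lower number a stronger inhibitor), the second highest of the three numbers. Compound 1 `CC(Sc1nc2c(cnn2C)c(=O)n1-c1ccccc1)c1ccccn1` gives 63 nM, with a 1.6-fold higher number from compound 1 to compound 3 (0.20 log units; within the scatter). Compound 2 `Cn1ncc2c(=O)n(-c3ccccc3)c(SC(C)(C)c3ccccc3)nc21` gives 2200 nM, with a 22-fold lower number from compound 2 to compound 3 (1.34 log units; beyond the scatter). Compound 4 `C[C@H](Sc1nc2c(cnn2C)c(=O)n1-c1ccccc1)c1ccccc1` differs from compound 3 in one place: a group of 8 heavy atoms (8 carbon; one six-membered aromatic ring of carbon only) in place of a group of 9 heavy atoms (8 carbon, 1 oxygen; one six-membered aromatic ring of carbon only), on a sulfur. Going by the values given here, two measured steps bear on this. The step of a 1.6-fold higher number from compound 1 to compound 3 (0.20 log units; within the scatter) shows that exchanging the aromatic ring on the chain carbon changes little, whereas a 35-fold higher number from compound 1 to compound 2 (1.54 log units; beyond the scatter) shows that 1-methyl-1-phenylethyl in place of 1-(pyridin-2-yl)ethyl costs heavily. Because compound 3 gives 100 nM and the nearer precedent is a 1.6-fold higher number from compound 1 to compound 3 (0.20 log units; within the scatter), compound 4 is expected to shift only by a 1.1-fold lower number from compound 3 to compound 4 (0.05 log units; within the scatter). Compound 4 is therefore estimated at 90 nM, in the range 30 nM to 300 nM.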

Compound 4, half-maximal inhibitory concentration: 1480 nM
Beside the measured number, compound 4's estimate is 16-fold (1.22 log units) below it, outside the stated range (above it).
By their numbers in this assay, from the lowest: compounds 1 and 3 (each within the scatter of the next); then compounds 4 and 2 (each within the scatter of the next).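

Removing the hydroxyl is not the neutral ring exchange that compounds 1 and 3 suggested: in this assay there is a 15-fold higher number from compound 3 to compound 4 (1.17 log units; beyond the scatter) and likewise a 23-fold higher number from compound 1 to compound 4 (1.37 log units; beyond the scatter) when the 1-phenylethyl replaces the pyridine-bearing group on the sulfur. With a 1.5-fold lower number from compound 2 to compound 4 (0.17 log units; within the scatter) the extra methyl on the chain carbon of compound 2 makes no readable difference, so the large loss goes with the unsubstituted phenyl ring in these compounds. Nothing available accounts for this loss.

Going by these compounds, it remains open whether a methoxy or an amine on the phenyl ring would match the hydroxyl. On these data alone, the opposite stereoisomer of compound 4 also remains open.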